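A few compounds are considered here, and "the series" means these few. Any claim that something is new, unique, unknown or untested is made for them only; others in the source may bear on it.

Series notes. In a functional assay on MCF7 cells (Homo sapiens) for cytotoxicity, read by sulforhodamine B assay, with a stated time of 48 h (on this read-out higher numbers stand for weaker inhibition of growth and lower numbers for stronger inhibition of growth), compound 1 `COC(=O)c1sc2cc(OC)ccc2c1C#Cc1ccccc1` gives 79600 nM, compound 2 `COC(=O)c1sc2cc(OC)ccc2c1C#Cc1ccccc1F` gives 11400 nM and compound 3 `COC(=O)c1sc2ccccc2c1C#Cc1ccccc1` gives 71600 nM. Compound 3 stands second highest of the three numbers; against compound 1 its value lies within the scatter, against compound 2 it is far apart. The one step shown that removes methoxy, a 1.1-fold lower number from compound 1 to compound 3 (0.05 log units; within the scatter), is within the scatter, so the core of compound 3 and the core of compound 1 look interchangeable on these numbers.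

The next compound, compound 4 `COC(=O)c1sc2ccccc2c1C#Cc1ccccc1F`, differs from compound 3 by fluoro in place of hydrogen on an aromatic carbon. Within the data shown here, the only measured step of this kind is a 7.0-fold lower number from compound 1 to compound 2 (0.84 log units; beyond the scatter), the same fluoro in place of hydrogen, made on the methoxy-bearing core. Because a 1.1-fold lower number from compound 1 to compound 3 (0.05 log units; within the scatter) shows the methoxy itself counts for nothing measurable here, that step is taken as the direct precedent and a lower number of similar size is expected for compound 4 in this assay , a 6.8-fold lower number from compound 3 to compound 4 (0.83 log units; beyond the scatter). Compound 4 is therefore estimated at 10500 nM, with a plausible range from 4000 nM to 28000 nM. The estimate rests on a single precedent step, so the range is kept wide.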

Compound 4, concentration for 50% growth inhibition: 40900 nM
Compound 4: the middle estimate sits 3.9-fold (0.59 log units) below what was measured; measured number above the stated range.
By their numbers in this assay, from the lowest: compound 2; then compounds 4, 3 and 1 (each within the scatter of the next).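

In this assay fluoro in place of hydrogen on an aromatic carbon, ortho to a large group, does not carry over from one core to the other, since a 1.8-fold lower number from compound 3 to compound 4 (0.24 log units; within the scatter) stays within the scatter and the two steps differ: the same change on two cores in this assay, a 7.0-fold lower number (0.84 log units; beyond the scatter) from compound 1 to compound 2 and a 1.8-fold lower number (0.24 log units; within the scatter) from compound 3 to compound 4, 4.0-fold (0.60 log units) apart, beyond the scatter of two such steps The methoxy, which counted for nothing measurable on the unsubstituted phenyl, does count once 2-fluorophenyl is present, with a 3.6-fold higher number from compound 2 to compound 4 (0.55 log units; beyond the scatter) beyond the scatter, so the cores of compound 1 and compound 3 are interchangeable only with phenyl and not with 2-fluorophenyl: the same change on two cores in this assay, a 1.1-fold lower number (0.05 log units; within the scatter) from compound 1 to compound 3 and a 3.6-fold higher number (0.55 log units; beyond the scatter) from compound 2 to compound 4, 4.0-fold (0.60 log units) apart, beyond the scatter of two such steps Across these four compounds the fluoro and methoxy steps therefore do not add independently, and only the compound carrying both, compound 2, stands apart from the others.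

As far as these compounds go, it remains open whether this dependence is specific to fluoro, which a chloro or an amine in the same place on the phenyl, read on both cores, would show. From the compounds shown here alone, it also remains open whether the methoxy itself is required, which a hydroxy or a longer alkoxy chain in its place on the core, paired with 2-fluorophenyl, would address.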